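A few compounds are considered here, and "the series" means these few. Any claim that something is new, unique, unknown or untested is made for them only; others in the source may bear on it.

Measured compounds:
compound 1 `COc1ccc2ncc(S(=O)(=O)c3ccc(C)c(Cl)c3)c(N3CCC(C)CC3)c2c1` gives 85%
compound 2 `Cc1ccc(S(=O)(=O)c2cnc3ccc(Cl)cc3c2N2CCC(C)CC2)cc1Cl` gives 81%

Both numbers come from an assay on isolated protein for displacement of a labelled ligand from metabotropic glutamate receptor 5 (Homo sapiens), with a stated time of 60 min, tested at 1 uM; on this read-out lower numbers stand for less inhibition and higher numbers for more inhibition at the one concentration tested (going by the name of the read-out). Compound 1 stands at the higher of the two measured numbers, but its gap to compound 2, a number 4 percentage points lower from compound 1 to compound 2 (within the scatter), lies within the scatter, so the two compounds cannot be told apart on this read-out. That one measured step exchanges a methoxy for a chloro on an aromatic carbon of the shared core; it does not touch the ring on the sulfonyl sulfur.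

The step considered here runs from compound 1 to compound 3 `COc1ccc2ncc(S(=O)(=O)c3cccc(F)c3)c(N3CCC(C)CC3)c2c1`. The change is 3-fluorophenyl in place of 3-chloro-4-methylphenyl on a sulfonyl sulfur. Among the measured compounds shown here, no measured step bears on this part of the molecule: the only step available, from compound 1 to compound 2, sits elsewhere and was within the scatter. Whether exchanging the ring on the sulfonyl sulfur moves the number in this assay, and in which direction, cannot be read from the two measured compounds. Some loss is a reasonable guess for a change of a whole aromatic ring, so the step is estimated at a number 25 percentage points lower from compound 1 to compound 3 (beyond the scatter), with wide uncertainty. Compound 3 is therefore expected to give about 60% in this assay, within a range from 25% to 90%.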

Compound 3, a percentage reported as inhibition, at one concentration (the size of the read-out at that concentration, not a potency): 68%
The estimate for compound 3 lay 8 percentage points below the measured number; low and high end bracket the measured number.
By their numbers in this assay, from the lowest: compound 3; then compounds 2 and 1 (each within the scatter of the next).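

In this assay, among the compounds shown here, putting 3-fluorophenyl in place of 3-chloro-4-methylphenyl on the sulfonyl sulfur gives a number 17 percentage points lower from compound 1 to compound 3 (beyond the scatter), so the group on this sulfur affects the read-out, whereas the only earlier step, at another place on the shared core, gave a number 4 percentage points lower from compound 1 to compound 2 (within the scatter). The effect is not all-or-nothing, as compound 3 still gives 68% at the one concentration tested, which is a size of inhibition at that concentration and not a potency. Nothing available explains why this exchange lowers the number.

The exchange alters the ring in more than one way at once: the methyl leaves and fluorine takes the place of chlorine, so this single step cannot show how much each part contributes, and a 3-chlorophenyl group on the same sulfur would help to separate them. Going by these compounds, how a ring carrying a different group, such as a nitrile, an amine or a carboxylic acid, would behave on this sulfur also remains open.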